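A few compounds are considered here, and "the series" means these few. Any claim that something is new, unique, unknown or untested is made for them only; others in the source may bear on it.

Among the measured compounds shown here, in a functional assay on HeLa cells (Homo sapiens) for inhibition, read by MTT assay, with a stated time of 72 h (a lower number here means a stronger inhibitor, a higher number a weaker inhibitor), two compounds have numbers so far. Compound 1 `COc1cc(O)c(CC=C(C)C)c(O)c1C(=O)/C=C/c1cccc([N+](=O)[O-])c1` gives 16500 nM, and compound 2 `COc1cc(/C=C/C(=O)c2c(OC)cc(OC)cc2OC)cc(OC)c1` gives 9200 nM. These two values lie within the usual scatter of repeated measurements, so compound 2 cannot be separated from compound 1 on the data at hand. Compound 3 `COc1cc(OC)c(C(=O)/C=C/c2cc(OC)c(OC)c(OC)c2)c(OC)c1` differs from compound 2 in one place: methoxy in place of hydrogen on an aromatic carbon. For the measured compounds named here, no measured pair shows what such a change does in this assay, so the expectation rests on little. Going by the values given here, no step clearly beyond the scatter is expected, only a slight lean towards a lower number, and the estimated step is a 1.7-fold lower number from compound 2 to compound 3 (0.22 log units; within the scatter). For compound 3 the expected value is 5500 nM, with an estimated range from 1500 nM to 20000 nM.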

Compound 3, half-maximal inhibitory concentration: 9900 nM
Estimate against measurement, compound 3: 1.8-fold (0.26 log units) below; the range from low to high includes it.
By their numbers in this assay, from the lowest: compounds 2, 3 and 1 (each within the scatter of the next).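

Methoxy in place of hydrogen on this aromatic carbon, ortho to two methoxy groups and para to a large group, gives a 1.1-fold higher number from compound 2 to compound 3 (0.03 log units; within the scatter) in this assay. This is the first pair among the compounds shown that differ in this one place, and it gives no sign that adding a methoxy group at this position changes the reading in this assay. No measurement at hand offers an explanation for this result.

As far as these compounds go, what remains open is whether a different group on the same carbon, such as a hydroxyl, an amine, a fluorine atom or a longer chain like ethoxy, would give a step beyond the scatter. This single pair also cannot show whether methoxy in place of hydrogen would behave the same way on a different core, such as that of compound 1.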